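Chloro on the Pendant Phenyl of the Trimethoxy Chalcone

The source may report more compounds than this note shows. Statements on the series, on what has been measured and on what is new or still open speak of the compounds shown alone.

Going by the values given here, compound 1 `COc1cc(/C=C/C(=O)c2cccc(-n3cc(-c4ccccc4)[nH]c3=O)c2)cc(OC)c1OC` is one of two compounds measured in a functional assay on K562 cells (Homo sapiens) for inhibition; on this read-out lower numbers stand for stronger inhibition of growth and higher numbers for weaker inhibition of growth. In this assay compound 1 gives 500 nM, the higher of the two numbers. The other is compound 2 `O=C(/C=C/c1cccc(O)c1)c1cccc(-n2cc(-c3ccc(Cl)cc3)[nH]c2=O)c1`, which in this assay gives 400 nM; the gap between the two lies within the usual scatter, so the two compounds cannot be ordered. Among the compounds with values here, no pair of measured compounds differs in one place only, and compound 2 differs from compound 1 in more than one place, so no single step has been measured.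

Compound 3 `COc1cc(/C=C/C(=O)c2cccc(-n3cc(-c4ccc(Cl)cc4)[nH]c3=O)c2)cc(OC)c1OC` has not yet been measured. It differs from compound 1 by chloro in place of hydrogen on an aromatic carbon, on an aromatic carbon para to a large group. Compound 2 carries the same 4-chlorophenyl and gives 400 nM in this assay, a number close to that of compound 1, though the further difference between those two leaves the effect of the chloro alone unknown. The step of a 1.3-fold lower number from compound 1 to compound 3 (0.10 log units; within the scatter) is expected to stay within the scatter, with no clear direction. Compound 3 is expected at 400 nM, with a range from 150 nM to 1100 nM.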

Compound 3, concentration for 50% growth inhibition: 3690 nM
Compound 3: middle estimate off by 9.2-fold (0.96 log units), on the low side, outside the stated range (above it).
By their numbers in this assay, from the lowest: compounds 2 and 1 (each within the scatter of the next); then compound 3.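

In this assay, going by these compounds alone, the change from phenyl to 4-chlorophenyl gives a 7.4-fold higher number from compound 1 to compound 3 (0.87 log units; beyond the scatter) and is the first single-place step that can be read. It shows that this place on the pendant phenyl, an aromatic carbon para to a large group, is not indifferent to substitution: with the trimethoxy chalcone held constant, one chlorine atom in place of hydrogen is enough to carry the number beyond the scatter, towards weaker inhibition of growth. Nothing measured on these compounds gives a reason for the size or direction of this step.

What stays open is whether the chloro has the same effect with the other side of the molecule changed, since compound 2 carries the same 4-chlorophenyl but has no partner among the compounds shown that differs from it by this change alone. Also open, as far as these compounds go, is whether the response at this place is particular to chloro or extends to other groups, such as fluoro, an amine or a carboxylic acid, so a single step gives no trend across substituents.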